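The source may report more compounds than this note shows. Statements on the series, on what has been measured and on what is new or still open speak of the compounds shown alone.

Of the compounds shown here, three built on one shared core have been measured in an ADME assay on Huh-7 cells (Homo sapiens) for cytotoxicity; a lower number here means that less compound is tolerated, a higher number that more compound is tolerated. Compound 1 `Cc1ccccc1-c1nn(-c2ccc(C(F)(F)F)cc2)cc1CNCCN1CCN(C)CC1` gives 11000 nM in this assay. Compound 2 `Cc1ccccc1-c1nn(-c2ccc(Br)cc2)cc1CNCCN1CCN(C)CC1` gives 9600 nM in this assay, and the step of a 1.1-fold lower number from compound 1 to compound 2 (0.06 log units; within the scatter) shows that these two numbers cannot be told apart. Compound 3 `Cc1ccccc1-c1nn(Cc2ccc(F)cc2)cc1CNCCN1CCN(C)CC1` sits at the limit of this assay, recorded as > 20000 nM, which is a limit and not a number (the limit of > 20000 nM in this assay, at which 1 of the 3 values shown sits). The steps of an at least 1.8-fold higher number from compound 1 to compound 3 (0.25 log units; that floor lies within the scatter) and an at least 2.0-fold higher number from compound 2 to compound 3 (0.31 log units; beyond the scatter) are therefore floors only.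

Compound 4 `Cc1ccccc1-c1nn(-c2cc(F)ccc2F)cc1CNCCN1CCN(C)CC1` has not yet been measured. It differs from compound 3 in one place: 2,5-difluorophenyl in place of 4-fluorobenzyl on an aromatic nitrogen. With this change compound 4 again carries a phenyl ring on the aromatic nitrogen, as do compound 1 and compound 2, where that ring bears trifluoromethyl or bromo rather than two fluorines. Since compound 1 gives 11000 nM and compound 2 gives 9600 nM in this assay, compound 4 is expected to return to numbers of that kind. The estimated step of an at least 1.5-fold lower number from compound 3 to compound 4 (0.18 log units; that floor lies within the scatter) is therefore expected to run downward from the limit. Compound 4 is estimated at 13000 nM in this assay, with a range from 6000 nM to 30000 nM.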

Compound 4, half-maximal cytotoxic concentration: > 20000 nM
Compound 4: a limit, no number (the forecaster's own chance of this, stated with the estimate: 25%); at least 1.5-fold (0.18 log units) between middle value and limit.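

A phenyl ring on the aromatic nitrogen is not enough on its own to bring this assay back to the numbers seen with trifluoromethyl or bromo on that ring: the 2,5-difluorophenyl group gives an at least 2.0-fold higher number from compound 2 to compound 4 (0.31 log units; beyond the scatter), and also an at least 1.8-fold higher number from compound 1 to compound 4 (0.25 log units; that floor lies within the scatter). What the phenyl ring carries therefore matters at this position, at least in the comparison with 4-bromophenyl, although the trifluoromethyl comparison alone would not settle this. Compound 3 and compound 4 both stand at a limit and not at a number, so the step between them cannot be read and the 4-fluorobenzyl and 2,5-difluorophenyl groups cannot be ranked against each other: the limit of > 20000 nM in this assay, at which 2 of the 4 values shown sit.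

The compounds shown leave open how far past the limit compound 3 and compound 4 lie, and whether the change on the phenyl ring depends on having fluorine rather than bromo or on the number and placing of the fluorines. A 4-fluorophenyl group would help to separate these readings, and a phenyl ring bearing an amine or a carboxylic acid would test how widely the result holds.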